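The compounds below may be only part of what the source reports. "The series", "measured", "known", "first", "only" and "open" are said of these compounds alone.

In an ADME assay on HEK293 cells (Homo sapiens) for cytotoxicity, read by MTT assay, with a stated time of 48 h (on this read-out lower numbers stand for stronger inhibition and higher numbers for weaker inhibition), compound 1, `CN(c1ccc(NC(=O)c2cc(C(F)(F)F)cc(C(F)(F)F)c2)cc1OCc1ccccc1C(F)(F)F)S(C)(=O)=O`, gives only a limit, > 500000 nM. Compound 2, `CN(c1ccc(NC(=O)c2ccc(C(F)(F)F)cc2C(F)(F)F)cc1OCc1ccccc1C(F)(F)F)S(C)(=O)=O`, shares the same atoms joined differently; how the two cores differ is not broken down here. In this assay compound 2 also gives only a limit, > 500000 nM. Compound 3, `Cc1ccc(C(F)(F)F)cc1COc1cc(NC(=O)c2cc(C(F)(F)F)cc(C(F)(F)F)c2)ccc1N(C)S(C)(=O)=O`, carries the change (2-methyl-5-(trifluoromethyl)phenyl in place of 2-(trifluoromethyl)phenyl on a saturated chain carbon bound to an oxygen on an aromatic ring), and in this assay compound 3 gives only a limit, > 500000 nM. The step that the two limits leave unreadable from compound 1 to compound 3 therefore cannot be read, because of the limit of > 500000 nM in this assay, at which 3 of the 3 values shown sit. Compound 4, `Cc1ccc(C(F)(F)F)cc1COc1cc(NC(=O)c2ccc(C(F)(F)F)cc2C(F)(F)F)ccc1N(C)S(C)(=O)=O`, is not yet measured and differs from compound 2 by the same change, (2-methyl-5-(trifluoromethyl)phenyl in place of 2-(trifluoromethyl)phenyl on a saturated chain carbon bound to an oxygen on an aromatic ring). The step from compound 2 to compound 4 is expected to be a step that the limit leaves unreadable from compound 2 to compound 4, resting on the unreadable earlier step and on the three limits. Compound 4 is therefore estimated at 700000 nM, between 300000 nM and 3000000 nM.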

Compound 4, half-maximal inhibitory concentration: > 500000 nM
Compound 4 gave a limit, no number; the forecaster's own chance of this, stated with the estimate: 90%; the middle value does not contradict the limit.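

In this assay compound 4, like compound 2, gives only a limit, so the step between them cannot be read: the limit of > 500000 nM in this assay, at which 4 of the 4 values shown sit. The compounds shown leave open whether 2-methyl-5-(trifluoromethyl)phenyl in place of 2-(trifluoromethyl)phenyl changes cytotoxicity at all.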